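A few compounds are considered here, and "the series" means these few. Any claim that something is new, unique, unknown or untested is made for them only; others in the source may bear on it.

Compound 3 `O=C(c1ccc(-c2nc(-c3ccc(Cl)cc3Cl)no2)s1)C(F)(F)F` gives 3000 nM in an assay on isolated protein for inhibition of protein deacetylase HDAC6 (Homo sapiens) (a higher number here means a weaker inhibitor, a lower number a stronger inhibitor), the highest of the three numbers shown. Compound 2 `O=C(c1ccc(-c2nc(-c3cccc(C(F)(F)F)c3)no2)s1)C(F)(F)F` gives 2450 nM, a gap from compound 3 within the scatter, while compound 1 `O=C(c1ccc(-c2nc(-c3ccccn3)no2)s1)C(F)(F)F` gives 500 nM; the step of a 6.0-fold higher number from compound 1 to compound 3 (0.78 log units; beyond the scatter) shows that swapping an aromatic nitrogen-containing ring for a chlorinated phenyl raised the number clearly. Compound 4 `Cc1cccc(-c2noc(-c3ccc(C(=O)C(F)(F)F)s3)n2)c1` carries 3-methylphenyl in place of 2,4-dichlorophenyl on an aromatic carbon. Among the compounds with values here, no measured step covers this exact swap; compound 2, with another substituted phenyl, sits close to compound 3, so a step of a 1.5-fold lower number from compound 3 to compound 4 (0.18 log units; within the scatter) from compound 3 to compound 4 is expected, within the scatter. The estimate for compound 4 in this assay is 2000 nM, ranging from 700 nM to 6000 nM.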

Compound 4, half-maximal inhibitory concentration: 680 nM
Estimate against measurement, compound 4: 2.9-fold (0.47 log units) above; the whole stated range lies above it.
By their numbers in this assay, from the lowest: compounds 1 and 4 (each within the scatter of the next); then compounds 2 and 3 (each within the scatter of the next).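

In this assay, a phenyl ring at this position does not by itself give a high number: the swap of trifluoromethyl for methyl gives a 3.6-fold lower number from compound 2 to compound 4 (0.56 log units; beyond the scatter), and replacing 2,4-dichlorophenyl with 3-methylphenyl gives a 4.4-fold lower number from compound 3 to compound 4 (0.64 log units; beyond the scatter). Pyridin-2-yl is also not needed for a low number, as 3-methylphenyl gives a 1.4-fold higher number from compound 1 to compound 4 (0.13 log units; within the scatter). Nothing measured here explains these shifts. Still open, on these data alone, is how a phenyl ring carrying an amine, a carboxylic acid or a longer chain would read in this assay.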